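Swapping nitro for chloro on a sugar-linked oxadiazole

The source may hold more compounds than are shown below. What is called first, only, known or untested is meant among the compounds shown, and "the series" means these compounds.

Compound 1 `COc1cc(-c2nc(CO[C@@H]3O[C@H](CSc4ncn[nH]4)[C@H]4OC5(CCCC5)O[C@@H]34)no2)cc(OC)c1OC` gives 37000 nM in a functional assay on HeLa cells (Homo sapiens) for antiproliferative activity, read by sulforhodamine B assay, with a stated time of 48 h; on this read-out lower numbers stand for stronger inhibition of growth and higher numbers for weaker inhibition of growth.
Compound 2 `O=[N+]([O-])c1ccc(-c2nc(CO[C@@H]3O[C@H](CSc4ncn[nH]4)[C@H]4OC5(CCCC5)O[C@@H]34)no2)cc1` gives 20000 nM in this assay.

These two values lie within the usual scatter of each other, as the step of a 1.9-fold lower number from compound 1 to compound 2 (0.27 log units; within the scatter) shows, so neither compound can be ranked above the other. Compound 3 `Clc1ccc(-c2nc(CO[C@@H]3O[C@H](CSc4ncn[nH]4)[C@H]4OC5(CCCC5)O[C@@H]34)no2)cc1` has not yet been measured. It differs from compound 2 in one place: chloro in place of nitro on an aromatic carbon. Among the compounds with values here, no measured pair shows this exact exchange. Within the data shown here, the one step that is available, a 1.9-fold lower number from compound 1 to compound 2 (0.27 log units; within the scatter), exchanged one group on this same ring for a very different one and still left the number within the scatter, which points to this ring tolerating substitution without much effect on the read-out. Compound 3 is therefore expected to show a step of a 1.3-fold higher number from compound 2 to compound 3 (0.10 log units; within the scatter), staying within the scatter. The estimate for compound 3 is 25000 nM, with a range from 8000 nM to 80000 nM.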

Compound 3, concentration for 50% growth inhibition: 14000 nM
The estimate for compound 3 lay 1.8-fold (0.25 log units) above the measured number; low and high end bracket the measured number.
By their numbers in this assay, from the lowest: compounds 3, 2 and 1 (each within the scatter of the next, the first and the last beyond it).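

Replacing nitro with chloro at this position, on an aromatic carbon para to a large group, gives a 1.4-fold lower number from compound 2 to compound 3 (0.15 log units; within the scatter) even though 3 heavy atoms give way to 1 heavy atom, so the read-out does not separate these two groups here. Within the data shown here, the wider change from 3,4,5-trimethoxyphenyl to 4-chlorophenyl gives a 2.6-fold lower number from compound 1 to compound 3 (0.42 log units; beyond the scatter) and is the first step here to pass beyond the scatter, showing that the groups on this ring can shift growth inhibition modestly, while compound 2 stays within the scatter of both other compounds. No measurement is available that explains this difference.

From the compounds shown here alone, it remains open whether an amine or a carboxylic acid in this place would stay within the same narrow span. Changes to the rest of the shared core also remain untested by these three compounds.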